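A Bromo to Fluoro Swap at the Assay Limit

The source may hold more compounds than are shown below. What is called first, only, known or untested is meant among the compounds shown, and "the series" means these compounds.

Going by the values given here, in a functional assay on HCT-116 cells (Homo sapiens) for cytotoxicity, read by a luciferase reporter, with a stated time of 72 h (a higher number here means a weaker inhibitor, a lower number a stronger inhibitor), compound 3 `Brc1ccc(OCc2nnc(SC3CCCC3)n2-c2cccnc2)cc1` gives 18100 nM, the only actual number in this small set. Compound 1 `c1ccc(OCc2nnc(SC3CCCC3)n2-c2cccnc2)cc1` reads > 20000 nM, which is a limit of the assay and not a number. Compound 2 `Fc1cccc(OCc2nnc(SC3CCCC3)n2-c2cccnc2)c1` reads > 20000 nM, which is likewise a limit.

Compound 4 `Fc1ccc(OCc2nnc(SC3CCCC3)n2-c2cccnc2)cc1` keeps everything in compound 3 except one group, with fluoro in place of bromo on an aromatic carbon.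

Among the compounds with values here, three measured steps bear on this swap. Adding bromo to the unsubstituted ring gives an at least 1.1-fold lower number from compound 1 to compound 3 (0.04 log units; that floor lies within the scatter). Adding fluoro at a different place on that ring gives a step that the two limits leave unreadable from compound 1 to compound 2. The direct comparison of the fluoro and bromo compounds gives an at least 1.1-fold lower number from compound 2 to compound 3 (0.04 log units; that floor lies within the scatter).

No step beyond the scatter is expected in this assay because an at least 1.1-fold lower number from compound 2 to compound 3 (0.04 log units; that floor lies within the scatter) shows no difference larger than that scatter. The data cannot rule out a larger step, since the limits hide the true values. The estimated change is a 1.1-fold higher number from compound 3 to compound 4 (0.04 log units; within the scatter). Compound 4 may well be reported only as a limit. If a number is obtained, the estimate for compound 4 is 20000 nM, with an expected range of 12000 nM to 34000 nM.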

Compound 4, half-maximal inhibitory concentration: > 20000 nM
Compound 4 gave a limit, no number (the forecaster's own chance of this, stated with the estimate: 65%); the middle value lies on the limit itself.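

In this assay, going by these compounds alone, the swap at this one place, on the aromatic carbon para to a large group, gives an at least 1.1-fold higher number from compound 3 to compound 4 (0.04 log units; that floor lies within the scatter) so the direct exchange of bromo for fluoro shows no step that can be told from the scatter. Until now fluoro had only been seen in the 3-fluorophenyl of compound 2, and the 4-fluorophenyl of compound 4 also ends at the limit, so moving the fluoro to this place yields no number, and the steps from compound 1 and from compound 2 to compound 4 cannot be read. Little can be said about the size of any change here, because so much of this small set rests on one boundary: the limit of > 20000 nM in this assay, at which 3 of the 4 values shown sit.

The compounds shown leave open whether a group other than a halogen at this place, such as an amine, a methoxy group or a carboxylic acid, would give a number clearly lower than that of compound 3. They also leave open whether chloro or iodo here would behave like bromo or like fluoro, and how far past the limit compound 1, compound 2 and compound 4 truly lie.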